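The compounds below may be only part of what the source reports. "The series", "measured", "known", "first", "only" and "open" are said of these compounds alone.

Measured compounds in the series:

compound 1 `O=C(OCCCc1cn(-c2ccnc3cc(Cl)ccc23)nn1)c1ccccc1`; in an ADME assay on HepG2 cells (Homo sapiens) for cytotoxicity, read by MTT assay, with a stated time of 24 h (a lower number here means that less compound is tolerated, a higher number that more compound is tolerated), compound 1 gives 1200000 nM.
compound 2 `O=C(OCCCc1cn(-c2ccnc3cc(Cl)ccc23)nn1)c1ccc(C(F)(F)F)cc1`; in this assay compound 2 gives > 2170000 nM, which is a limit of the assay.
compound 3 `O=C(OCc1cn(-c2ccnc3cc(Cl)ccc23)nn1)c1ccccc1`; in this assay compound 3 gives > 2740000 nM, which is a limit of the assay.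

The change from compound 1 to compound 2 is trifluoromethyl in place of hydrogen on an aromatic carbon. It gave an at least 1.8-fold higher number from compound 1 to compound 2 (0.25 log units; that floor lies within the scatter); the value of compound 2 is a limit (the limit of > 2170000 nM in this assay, at which 1 of the 3 values shown sits), so only a floor is known for that step. The difference between the core of compound 1 and the core of compound 3 is not broken down here.

Compound 4 `O=C(OCc1cn(-c2ccnc3cc(Cl)ccc23)nn1)c1ccc(C(F)(F)F)cc1` is not yet measured. It stands to compound 3 as trifluoromethyl in place of hydrogen on an aromatic carbon, the same change as that from compound 1 to compound 2. Compound 3 already sits at a limit (the limit of > 2740000 nM in this assay, at which 1 of the 3 values shown sits), so the step to compound 4 is expected as a step that the limit leaves unreadable from compound 3 to compound 4, and a limit rather than a number is considered likely. Compound 4 is estimated at 3500000 nM in this assay, between 1500000 nM and 8000000 nM.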

Compound 4, half-maximal cytotoxic concentration: 1070000 nM
Compound 4: middle estimate off by 3.3-fold (0.51 log units), on the high side, and the stated range ends above it.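

In this assay, trifluoromethyl in place of hydrogen on the aromatic carbon gives an at least 2.5-fold lower number from compound 3 to compound 4 (0.40 log units; beyond the scatter). Set beside the earlier step, the change does not carry over as one fixed shift between these two cores: the same change on two cores in this assay, an at least 1.8-fold higher number (0.25 log units; that floor lies within the scatter) from compound 1 to compound 2 and an at least 2.5-fold lower number (0.40 log units; beyond the scatter) from compound 3 to compound 4, at least 4.6-fold (0.66 log units) apart, beyond the scatter of two such steps The true size of each step remains unknown, with compound 2 and compound 3 each sitting at a limit so that only floors are available, and one pair of cores gives no reason for the difference in direction.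

Still open, on these data alone, is whether a longer chain than that of compound 1 keeps the direction seen from compound 1 to compound 2. Also open, as far as these compounds go, is whether a nitrile or a carboxylic acid in place of trifluoromethyl would behave differently on the two cores.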